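Aminochromene spirooxindole triazoles: aryl swap on the triazole nitrogen

This account rests on a few compounds, and the source may have more. Where it says the series, first, only, none or still open, it means among the compounds named here.

Compounds with values so far:
compound 1, `N#CC1=C(N)Oc2c(c3nc4ccccc4nc3c3ccccc23)C12C(=O)N(Cc1cnnn1-c1ccc(Br)cc1)c1ccccc12`, in a functional assay on MCF7 cells (Homo sapiens) for antiproliferative activity, read by MTT assay, with a stated time of 48 h (on this read-out higher numbers stand for weaker inhibition and lower numbers for stronger inhibition), compound 1 gives 36600 nM.
compound 2, `N#CC1=C(N)Oc2c(c3nc4ccccc4nc3c3ccccc23)C12C(=O)N(Cc1cnnn1-c1ccccc1Br)c1ccccc12`; in this assay compound 2 reaches only the assay limit of > 50000 nM.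
compound 3, `N#CC1=C(N)Oc2c(N)cc3nc4ccccc4nc3c2C12C(=O)N(Cc1cnnn1-c1cccc(C(F)(F)F)c1)c1ccccc12`, in this assay compound 3 gives 31600 nM.

Compound 3 and compound 1 sit within the usual scatter of each other, so no order between them can be read; the value of compound 2 is a limit and not a number, as noted in the limit of > 50000 nM in this assay, at which 1 of the 3 values shown sits.

Compound 4, `N#CC1=C(N)Oc2c(N)cc3nc4ccccc4nc3c2C12C(=O)N(Cc1cnnn1-c1c(Cl)cc(Cl)cc1Cl)c1ccccc12`, is not yet measured. It differs from compound 3 by 2,4,6-trichlorophenyl in place of 3-(trifluoromethyl)phenyl on an aromatic nitrogen. Among the measured compounds shown here, the only measured step at this position, an at least 1.3-fold higher number from compound 1 to compound 2 (0.13 log units; that floor lies within the scatter), moves one halogenated phenyl to another on the same aromatic nitrogen and gives a floor that lies within the scatter. Both measured changes at this position therefore leave the read-out essentially where it was, and the change from compound 3 to compound 4 is expected to do the same, with no step beyond the scatter in either direction.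

Compound 4 is expected to give 34000 nM in this assay, in the range 14000 nM to 80000 nM. That estimate means a step of a 1.1-fold higher number from compound 3 to compound 4 (0.03 log units; within the scatter), expected to stay within the scatter.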

Compound 4, half-maximal inhibitory concentration: 37800 nM
Beside the measured number, compound 4's estimate is 1.1-fold (0.05 log units) below it; the measured number falls inside the stated range.
By their numbers in this assay, from the lowest: compounds 3, 1 and 4 (each within the scatter of the next). At a limit, above all of these: compound 2.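

Compound 2 is a limit and not a number, which left the earlier step at this position with only a floor. In this assay, among the compounds shown here, the new pair gives the first step here with a number at both ends, a 1.2-fold higher number from compound 3 to compound 4 (0.08 log units; within the scatter), so on the core of compound 3 the 3-(trifluoromethyl)phenyl and 2,4,6-trichlorophenyl groups cannot be told apart, although they differ in their halogen and in the number and placing of their ring substituents. Nothing measured here explains why this exchange leaves the read-out within the scatter.

Both groups in this pair are carbon-only aromatic rings with no hydrogen-bond donors or acceptors, so the result says nothing about an aryl group carrying an amine or a carboxylic acid, or about a saturated ring or a longer alkyl chain on the same aromatic nitrogen. The core of compound 1 and the core of compound 3 also remain unconnected, since no pair shown carries the same aryl group on both cores, and the contribution of the core to the read-out cannot be separated from that of the aryl group.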